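A few compounds are considered here, and "the series" means these few. Any claim that something is new, unique, unknown or untested is made for them only; others in the source may bear on it.

Measured so far in a functional assay on cells (Homo sapiens) for antiproliferative activity, read by WST assay, with a stated time of 3 days; a lower number here means a stronger inhibitor, a higher number a weaker inhibitor:
- compound 1 `O=c1cc(I)n([C@@H]2O[C@H](CO)[C@@H](O)[C@H]2O)c(=O)[nH]1`: 27800 nM
- compound 2 `[N-]=[N+]=Nc1cc(=O)[nH]c(=O)n1[C@@H]1O[C@H](CO)[C@@H](O)[C@H]1O`: > 50000 nM (a limit)
- compound 3 `O=c1cc(NO)n([C@@H]2O[C@H](CO)[C@@H](O)[C@H]2O)c(=O)[nH]1`: > 50000 nM (a limit)

Compound 3 sits at the limit of > 50000 nM in this assay, at which 2 of the 3 values shown sit, so only a limit is known for it.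

Compound 4 `O=Cc1cc(=O)[nH]c(=O)n1[C@@H]1O[C@H](CO)[C@@H](O)[C@H]1O` carries formyl in place of hydroxyamino on an aromatic carbon.

Three measured steps at this place bear on the change: an at least 1.7-fold higher number from compound 1 to compound 2 (0.25 log units; that floor lies within the scatter), an at least 1.7-fold higher number from compound 1 to compound 3 (0.25 log units; that floor lies within the scatter) and a step that the two limits leave unreadable from compound 2 to compound 3. Neither of the first two goes beyond the scatter, and the third cannot be read. Only compound 1 gives a number, so no step beyond the scatter is expected in this assay, and a further limit is quite likely.

The estimated step is an at least 1.2-fold lower number from compound 3 to compound 4 (0.09 log units; that floor lies within the scatter).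

Compound 4 is estimated at 40000 nM, with an expected range of 12000 nM to 100000 nM.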

Compound 4, half-maximal inhibitory concentration: > 50000 nM
Compound 4 was reported as a limit; the forecaster's own chance of this, stated with the estimate: 55%; at least 1.2-fold (0.09 log units) between middle value and limit.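

In this assay, among these compounds, formyl is a third group on this aromatic carbon to give only a limit, which leaves iodo in compound 1 as the only group here with a number: the limit of > 50000 nM in this assay, at which 3 of the 4 values shown sit.
Against iodo, the step is an at least 1.7-fold higher number from compound 1 to compound 4 (0.25 log units; that floor lies within the scatter) and is the only readable one; the steps among compound 2, compound 3 and compound 4 cannot be read.

Going by these compounds, whether an amine or a carboxylic acid on this aromatic carbon would give a number remains open. Also open, on these data alone, is whether any group here differs from iodo beyond the scatter.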